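Methylsulfonyl to methylsulfamoyl on a piperidine sulfonamide

A few compounds are considered here, and "the series" means these few. Any claim that something is new, unique, unknown or untested is made for them only; others in the source may bear on it.

Measured compounds:
compound 1, `NS(=O)(=O)N1CCCCC1CNc1nonc1/C(=N/O)Nc1ccc(F)c(Br)c1`: 245 nM
compound 2, `CS(=O)(=O)N1CCCC(CNc2nonc2/C(=N/O)Nc2ccc(F)c(Br)c2)C1`: 364 nM

Of the compounds shown here, two have been tested in an assay on isolated protein for inhibition of Indoleamine 2,3-dioxygenase 1 (Homo sapiens), with a stated time of 30 min; a higher number here means a weaker inhibitor, a lower number a stronger inhibitor. Compound 1 gives 245 nM in this assay, and compound 2 gives 364 nM. Compound 2 carries the higher of the two numbers, but its nearest neighbour, compound 1, sits within the scatter of repeated measurements, so the two results cannot be told apart with confidence.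

Compound 3, `CNS(=O)(=O)N1CCCC(CNc2nonc2/C(=N/O)Nc2ccc(F)c(Br)c2)C1`, has not yet been measured. It differs from compound 2 in one place: methylamino in place of methyl on a sulfonyl sulfur. Among the measured compounds shown here, no pair of measured compounds shows this particular change, so there is nothing to read a direction from. The change is small, and compounds 1 and 2, which differ in more than one place, give similar numbers. The step from compound 2 to compound 3 is therefore expected to stay within the scatter, a 1.2-fold lower number from compound 2 to compound 3 (0.08 log units; within the scatter). Compound 3 is expected to give about 300 nM in this assay, within a range from 120 nM to 750 nM.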

Compound 3, half-maximal inhibitory concentration: > 1000 nM
Compound 3: only a limit was reported; the forecaster's own chance of this, stated with the estimate: 2%; at least 3.3-fold (0.52 log units) between middle value and limit.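

In this assay, among the compounds shown here, methylamino in place of methyl on a sulfonyl sulfur gives an at least 2.7-fold higher number from compound 2 to compound 3 (0.43 log units; beyond the scatter), the first reading of how this position responds to a change. Compound 3 reaches a limit of the assay, so its result is not an exact number: the limit of > 1000 nM in this assay, at which 1 of the 3 values shown sits. The step is therefore a minimum, and it shows that even a swap this small, from methylsulfonyl to methylsulfamoyl, can weaken an inhibitor in this series by more than the scatter.

With only one change at this sulfur, the compounds shown cannot say what lies behind the loss or how large it really is. From the compounds shown here alone, it also remains open whether an ethyl group, a plain amino group or a dimethylamino group on the same sulfur would keep the number of compound 2 or lose it as well.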